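Hydroxymethyl in place of the bromopropenyl chain on compound 3

A few compounds are considered here, and "the series" means these few. Any claim that something is new, unique, unknown or untested is made for them only; others in the source may bear on it.

Compound 3 `COc1ccc(CN(C(=O)/C=C/CBr)c2cc(OC)c(OC)c(OC)c2)cc1O` holds the lowest number among the three measured in a functional assay on MGC-803 cells (Homo sapiens) for inhibition, read by MTT assay, with a stated time of 48 h (on this read-out lower numbers stand for stronger inhibition and higher numbers for weaker inhibition), where compound 3 gives 71 nM. Compound 2 `COc1ccc(CN(C(=O)CBr)c2cc(OC)c(OC)c(OC)c2)cc1O` gives 140 nM in this assay, and compound 1 `COc1ccc(CN(C(=O)C[Se]C#N)c2cc(OC)c(OC)c(OC)c2)cc1O` gives 270 nM. The gap a 2.0-fold lower number from compound 2 to compound 3 (0.29 log units; within the scatter) stays within the scatter, as does a 1.9-fold lower number from compound 1 to compound 2 (0.29 log units; within the scatter), while a 3.8-fold lower number from compound 1 to compound 3 (0.58 log units; beyond the scatter) is the only difference among the three that clears it. Every measured step exchanges one group on a carbonyl carbon, and all three groups tried there carry a bromine or a selenium.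

Compound 4 `COc1ccc(CN(C(=O)CO)c2cc(OC)c(OC)c(OC)c2)cc1O` changes the same position: hydroxymethyl in place of 3-bromoprop-1-en-1-yl on a carbonyl carbon. Hydroxymethyl brings one hydrogen-bond donor and one hydrogen-bond acceptor, which none of the measured groups at this carbonyl carbon had, so no measured step tracks this change directly. The measured steps show that swaps at this position have moved this assay by at most a modest amount. Given that compound 3 already gives 71 nM, and that the change departs further from the measured groups than any measured swap did, a rise in number is expected, most likely beyond the scatter, by a 17-fold higher number from compound 3 to compound 4 (1.23 log units; beyond the scatter). Compound 4 is therefore estimated at 1200 nM, with a range from 250 nM to 6000 nM.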

Compound 4, half-maximal inhibitory concentration: 160 nM
Compound 4: the middle estimate sits 7.5-fold (0.88 log units) above what was measured, outside the stated range (below it).
By their numbers in this assay, from the lowest: compounds 3, 2, 4 and 1 (each within the scatter of the next, the first and the last beyond it).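

In this assay, among these compounds, hydroxymethyl is the first group at this carbonyl carbon without bromine or selenium, and the number stays close to those of the two shorter groups: a 1.1-fold higher number from compound 2 to compound 4 (0.06 log units; within the scatter) and a 1.7-fold lower number from compound 1 to compound 4 (0.23 log units; within the scatter) both leave the read-out within the scatter. So among the compounds with a short chain, a hydroxy group serves as well as bromo or the selenium-bearing group, and a number in this range does not depend on either element; compound 3 is the one exception, with a 2.3-fold higher number from compound 3 to compound 4 (0.35 log units; beyond the scatter) clearing the scatter, though only modestly. No measurement at hand accounts for how closely hydroxymethyl tracks the bromine and selenium groups or for the remaining gap to the bromopropenyl chain.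

The shown compounds do not separate chain length from the end group, and 3-hydroxyprop-1-en-1-yl at this carbonyl carbon would address exactly that, as its only difference from the chain in compound 3 would be hydroxy in place of bromo. Also open, from the compounds shown here alone, is how a plain methyl, an aminomethyl group or a carboxylic acid would read at the same carbonyl carbon, and so whether any end group is needed at all.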